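Trimming a Naphthalene Sulfonamide Endothelin Antagonist

A few compounds are considered here, and "the series" means these few. Any claim that something is new, unique, unknown or untested is made for them only; others in the source may bear on it.

In an assay on VSM-A10 cells for antagonist activity at Endothelin-1 receptor (Rattus norvegicus); a lower number here means a stronger inhibitor, a higher number a weaker inhibitor: compound 1 `Cc1noc(NS(=O)(=O)c2cccc3ccccc23)c1C` gives 20000 nM; compound 2 `Cc1noc(NS(=O)(=O)c2cccc3c(N/C(S)=N/c4ccccc4)cccc23)c1C` gives 150 nM.

Within the data shown here, compound 2 stands lowest of these two numbers, its only neighbour being compound 1 with 20000 nM. Compound 3 `Cc1noc(NS(=O)(=O)c2cccc3c(CN(C)C)cccc23)c1C` differs from compound 2 in one place: a group of 4 heavy atoms (3 carbon, 1 nitrogen; no ring) in place of a group of 10 heavy atoms (7 carbon, 2 nitrogen, 1 sulfur; one six-membered aromatic ring of carbon only), on an aromatic carbon. Among the measured compounds shown here, the one step that bears on this change is a 130-fold lower number from compound 1 to compound 2 (2.12 log units; beyond the scatter), which shows how much the group now leaving was worth. Taking it out again, with only a small group in its place, is expected to give back most of that loss in this assay. Compound 3 is therefore expected near 5000 nM, within 1500 nM to 20000 nM. That expectation means a step of a 33-fold higher number from compound 2 to compound 3 (1.52 log units; beyond the scatter).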

Compound 3, half-maximal inhibitory concentration: 2800 nM
Compound 3: middle estimate off by 1.8-fold (0.25 log units), on the high side; the range from low to high includes it.
By their numbers in this assay, from the lowest: compound 2; then compound 3; then compound 1.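

In this assay the (dimethylamino)methyl group alone, with no ring, already improves on hydrogen at this aromatic carbon: the step is a 7.1-fold lower number from compound 1 to compound 3 (0.85 log units; beyond the scatter). So part of the gain seen with compound 2 does not need the six-membered aromatic ring, yet the larger group still counts for much, with a 19-fold higher number from compound 2 to compound 3 (1.27 log units; beyond the scatter). No measurement here explains either step.

From the compounds shown here alone, whether a simple amine or a longer chain ending in a phenyl ring would come closer to compound 2 stays open.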